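Swapping the Urea Side Chain for an Acrylate Ester

The source may report more compounds than this note shows. Statements on the series, on what has been measured and on what is new or still open speak of the compounds shown alone.

Measured so far in a functional assay with Oryctolagus cuniculus as the target; a higher number here means a weaker inhibitor, a lower number a stronger inhibitor:
compound 1 `COc1ccc(-c2nc(N=C(N)N)sc2-c2ccc(OC)cc2)cc1` gives 31000 nM.
compound 2 `COc1ccc(-c2nc(/N=C(\N)NC3CCCCC3)sc2-c2ccc(OC)cc2)cc1` gives > 1000 nM, which is a limit of the assay rather than a number.
compound 3 `COc1ccc(-c2nc(CNC(=O)N3CCOCC3)sc2-c2ccc(OC)cc2)cc1` gives 660 nM.

Among the two numbers, compound 3 stands lowest; the nearest number lies a step of a 47-fold lower number from compound 1 to compound 3 (1.67 log units; beyond the scatter) away. Compound 4 `CCOC(=O)/C=C/c1nc(-c2ccc(OC)cc2)c(-c2ccc(OC)cc2)s1` differs from compound 3 in one place: 2-(ethoxycarbonyl)ethenyl in place of (((morpholin-4-yl)carbonyl)amino)methyl on an aromatic carbon. For the measured compounds named here, two measured steps concern that same carbon. The exchange a 47-fold lower number from compound 1 to compound 3 (1.67 log units; beyond the scatter) was large, while the exchange an at least 1.5-fold lower number from compound 2 to compound 3 (0.18 log units; that floor lies within the scatter) can be read only as a floor because compound 2 sits at the limit of > 1000 nM in this assay, at which 1 of the 3 values shown sits. Exchanges at this carbon have moved the read-out widely, and compound 3 holds the lowest number seen, so compound 4 is expected to shift toward weaker inhibition by about a 7.6-fold higher number from compound 3 to compound 4 (0.88 log units; beyond the scatter). Compound 4 is estimated at 5000 nM, within a range from 1000 nM to 25000 nM.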

Compound 4, half-maximal inhibitory concentration: 20 nM
Compound 4: middle estimate off by 250-fold (2.40 log units), on the high side; the measured number lies below the stated range.
By their numbers in this assay, from the lowest: compound 4; then compound 3; then compound 1.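

In this assay, the ring carbon next to the ring nitrogen and the ring sulfur accepts 2-(ethoxycarbonyl)ethenyl, a side chain with no ring and no hydrogen-bond donor, with a 33-fold lower number from compound 3 to compound 4 (1.52 log units; beyond the scatter). For the compounds shown here, the gap to the first compound of the series widens to a 1600-fold lower number from compound 1 to compound 4 (3.19 log units; beyond the scatter). The remaining step, an at least 50-fold lower number from compound 2 to compound 4 (1.69 log units; beyond the scatter), is only a floor, since compound 2 gives a limit rather than a number: the limit of > 1000 nM in this assay, at which 1 of the 4 values shown sits.

Which part of the new side chain matters stays open, as ester and double bond enter together. A carboxylic acid or an amide in place of the ethyl ester, or a saturated chain in place of the double bond, would separate them.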